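Methoxy for methyl on the shared core: cytotoxicity notes

This account rests on a few compounds, and the source may have more. Where it says the series, first, only, none or still open, it means among the compounds named here.

Compound 1 `Cc1cccc2c(NCc3ccco3)nc(NC(C)C)nc12` and compound 3 `COc1cccc2c(NCc3ccco3)nc(NC(C)C)nc12` share one core; compound 2 `Cc1ccc2nc(NC(C)C)nc(NCc3ccco3)c2c1` has the same atoms joined differently, and the difference between the two cores is not broken down here. In an ADME assay on J774.A1 cells (Mus musculus) for cytotoxicity, read by MTT assay, with a stated time of 72 h (a higher number here means that more compound is needed for the effect, a lower number that less compound is needed), compound 1 gives only a limit, > 33000 nM. Compound 2 likewise gives only a limit, > 33000 nM. Compound 3 gives 30000 nM. The change methoxy in place of methyl on an aromatic carbon made an at least 1.1-fold lower number from compound 1 to compound 3 (0.04 log units; that floor lies within the scatter), a step that rests on (the limit of > 33000 nM in this assay, at which 2 of the 3 values shown sit). Compound 4 `COc1ccc2nc(NC(C)C)nc(NCc3ccco3)c2c1` carries the same kind of change, (methoxy in place of methyl on an aromatic carbon), the place now meta to a fused ring and para to a fused ring rather than ortho and meta to one. The step to compound 4 is expected to be an at least 1.1-fold lower number from compound 2 to compound 4 (0.04 log units; that floor lies within the scatter), resting on the limit of compound 2, > 33000 nM, and on the earlier step of an at least 1.1-fold lower number from compound 1 to compound 3 (0.04 log units; that floor lies within the scatter). Compound 4 is therefore expected near 30000 nM, between 15000 nM and 60000 nM, with a fair chance of only a limit again.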

Compound 4, half-maximal effective concentration: 14000 nM
Beside the measured number, compound 4's estimate is 2.1-fold (0.33 log units) above it; measured number outside the range, below it.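

In this assay, methoxy in place of methyl on an aromatic carbon gives an at least 2.3-fold lower number from compound 2 to compound 4 (0.37 log units; beyond the scatter), a step beyond the scatter on this core, whereas the floor on the core of compound 1 lies within it. The data therefore neither show that the change carries over equally between the two cores nor show that it differs between them: the same change on two cores in this assay, an at least 1.1-fold lower number (0.04 log units; that floor lies within the scatter) from compound 1 to compound 3 and an at least 2.3-fold lower number (0.37 log units; beyond the scatter) from compound 2 to compound 4; the limit leaves it open whether they differ. Both steps start from a limit, so each is a floor rather than a measured size, and two cores give no rule for the series: the limit of > 33000 nM in this assay, at which 2 of the 4 values shown sit.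

Going by these compounds, whether the step holds for an ethoxy group, a chlorine or an amine on the same aromatic carbon stays open. Also open, on these data alone, is where compound 1 and compound 2 would read beyond their limits.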